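A few compounds are considered here, and "the series" means these few. Any claim that something is new, unique, unknown or untested is made for them only; others in the source may bear on it.

Compound 3 `COc1ccc(F)cc1CNCCCNc1ccnc2cc(-c3ccc(C(C)(C)C)cc3)ccc12` gives the highest of the three numbers in a physicochemical assay for solubility, with a stated time of 18 h, at pH 7.4 (a lower number here means a less soluble compound, a higher number a more soluble compound), at 32000 nM. Compound 1 `COc1ccc(F)cc1CNCCCNc1ccnc2cc(Oc3ccc(F)cc3)ccc12` gives 14500 nM in this assay, and compound 2 `COc1cccc(CNCCCNc2ccnc3cc(CC4CCCCC4)ccc23)c1O` gives 4200 nM. Among the compounds with values here, the only measured step at the same aromatic carbon is a 2.2-fold higher number from compound 1 to compound 3 (0.34 log units; beyond the scatter), a modest one. Compound 4 `COc1ccc(F)cc1CNCCCNc1ccnc2cc(CC3CCCCC3)ccc12` is the next compound; it differs from compound 3 by cyclohexylmethyl in place of 4-(tert-butyl)phenyl on an aromatic carbon. Compound 2 carries the cyclohexylmethyl group on a different core, and its value in this assay lies well under that of compound 3, so no step between the two is shown. A lower number is therefore expected for compound 4, by a step of a 3.6-fold lower number from compound 3 to compound 4 (0.55 log units; beyond the scatter). Compound 4 is estimated at 9000 nM, between 3000 nM and 25000 nM.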

Compound 4, solubility: 4200 nM
Compound 4: the middle estimate sits 2.1-fold (0.33 log units) above what was measured; the range from low to high includes it.
By their numbers in this assay, from the lowest: compounds 2 and 4 (each within the scatter of the next); then compound 1; then compound 3.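

In this assay, cyclohexylmethyl on this aromatic carbon gives a lower number than either group measured there before: against 4-(tert-butyl)phenyl the result is a 7.6-fold lower number from compound 3 to compound 4 (0.88 log units; beyond the scatter), and against 4-fluorophenoxy it is a 3.5-fold lower number from compound 1 to compound 4 (0.54 log units; beyond the scatter). With cyclohexylmethyl held in place, 5-fluoro-2-methoxyphenyl in place of 2-hydroxy-3-methoxyphenyl gives no change at the digits printed from compound 2 to compound 4 (within the scatter), so at this pair that change on the chain does not move the number. No measurement offered here explains these differences. As far as these compounds go, whether an amine or a carboxylic acid on this aromatic carbon would raise the number further remains open.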